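This account rests on a few compounds, and the source may have more. Where it says the series, first, only, none or still open, it means among the compounds named here.

Among the compounds with values here, compound 3 `CCOCc1c(C)coc1-c1ccc2c(CC)cccc2c1OC` is the one compound of the three that gives an actual number in a functional assay on MDA-MB-231 cells (Homo sapiens) for cytotoxicity, read by MTT assay, with a stated time of 72 h (a lower number here means that less compound is needed, a higher number that more compound is needed for the effect), where compound 3 gives 9.1 ug/mL. Compound 1 `CCc1cccc2c(OC)c(-c3occ(C)c3C(=O)NC)ccc12` reaches only a limit in this assay, and in this assay compound 1 gives > 10 ug/mL. Compound 2 `CCc1cccc2c(OC)c(-c3occ(C)c3CO)ccc12` likewise stops at a limit, and in this assay compound 2 gives > 10 ug/mL. Both of those values sit at the limit of > 10 ug/mL in this assay, at which 2 of the 3 values shown sit. The step of an at least 1.0-fold lower number from compound 1 to compound 3 (0.04 log units; that floor lies within the scatter) and the step of an at least 1.0-fold lower number from compound 2 to compound 3 (0.04 log units; that floor lies within the scatter) are therefore floors that lie within the scatter, and the step that the two limits leave unreadable from compound 1 to compound 2 cannot be read at all.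

Compound 4 `CCc1cccc2c(OC)c(-c3occ(C)c3COCC(F)(F)F)ccc12` differs from compound 3 by trifluoromethyl in place of methyl on a saturated chain carbon bound to an oxygen on a saturated carbon. Within the data shown here, none of the measured steps touches this position: the steps from compound 1 and compound 2 to compound 3 alter the group on the aromatic carbon or the hydrogen on the oxygen, not the terminal carbon of the ethoxymethyl chain. There is no basis in these numbers for expecting a step beyond the scatter in this assay, so the expected step of a 1.0-fold lower number from compound 3 to compound 4 (0.00 log units; within the scatter) is taken as essentially flat. Compound 4 is accordingly estimated at 9 ug/mL in this assay, with a range from 4 ug/mL to 20 ug/mL.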

Compound 4, concentration for half-maximal effect: 5.3 ug/mL
Beside the measured number, compound 4's estimate is 1.7-fold (0.23 log units) above it; the range from low to high includes it.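

In this assay, the step of a 1.7-fold lower number from compound 3 to compound 4 (0.23 log units; within the scatter) is the only one shown that joins two actual numbers, and it is also the only one that alters the saturated chain carbon bound to an oxygen on a saturated carbon. It shows that trifluoromethyl can stand in place of methyl at this end of the chain without a step beyond the scatter, so this change gives no sign that the position responds to it in this assay. The step of an at least 1.8-fold lower number from compound 2 to compound 4 (0.27 log units; that floor lies within the scatter) and the step of an at least 1.8-fold lower number from compound 1 to compound 4 (0.27 log units; that floor lies within the scatter) remain floors within the scatter, so compound 4 does not yet set the ether groups apart from hydroxymethyl or methylcarbamoyl: the limit of > 10 ug/mL in this assay, at which 2 of the 4 values shown sit.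

The compounds shown leave open whether any group at this end of the chain can move the number beyond the scatter, for instance a longer chain such as propyl, an amine or a carboxylic acid. They also leave open how far compound 1 and compound 2 actually lie from compound 4, since only limits stand for those two.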